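The source may hold more compounds than are shown below. What is called first, only, known or untested is meant among the compounds shown, and "the series" means these compounds.

Measured compounds:
compound 1, `CN(c1ccc(Oc2ncnc3ccsc23)cc1)c1nccc(N2CCCC2)n1`, 63.6% in a functional assay on HCT-116 cells (Homo sapiens) for inhibition, read by MTT assay, with a stated time of 72 h, tested at 20 uM; on this read-out lower numbers stand for less inhibition and higher numbers for more inhibition at the one concentration tested (going by the name of the read-out)
compound 2, `CN(c1ccc(Oc2ncnc3ccsc23)cc1)c1nccc(N2CCc3ccccc3C2)n1`, 58.3% in this assay
compound 3, `c1cc(N2CCCC2)nc(Nc2ccc(Oc3ncnc4sccc34)cc2)n1`, 54.4% in this assay

Compound 1 and compound 2 share a core and differ by 1,2,3,4-tetrahydroisoquinolin-2-yl in place of pyrrolidin-1-yl on an aromatic carbon, and in this assay this gave a number 5.3 percentage points lower from compound 1 to compound 2 (within the scatter). Compound 3 carries a different core; how the two cores differ is not broken down here. Compound 4, `c1ccc2c(c1)CCN(c1ccnc(Nc3ccc(Oc4ncnc5sccc45)cc3)n1)C2`, has not yet been measured in this assay. It differs from compound 3 by 1,2,3,4-tetrahydroisoquinolin-2-yl in place of pyrrolidin-1-yl on an aromatic carbon, the same change as between compound 1 and compound 2, at the same place in both pairs. Because that change gave a number 5.3 percentage points lower from compound 1 to compound 2 (within the scatter) on the first core, compound 4 is expected to show a number 4.4 percentage points lower from compound 3 to compound 4 (within the scatter). On this basis compound 4 is estimated at 50% in this assay, most likely between 38% and 62%.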

Compound 4, a percentage reported as inhibition, at one concentration (the size of the read-out at that concentration, not a potency): 18.1%
For compound 4 the middle estimate is 31.9 percentage points above the measured one, and the stated range ends above it.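

In this assay the change from pyrrolidin-1-yl to 1,2,3,4-tetrahydroisoquinolin-2-yl gave a number 36.3 percentage points lower from compound 3 to compound 4 (beyond the scatter), and its size did not carry over from one core to the other: the same change on two cores in this assay, a number 5.3 percentage points lower (within the scatter) from compound 1 to compound 2 and a number 36.3 percentage points lower (beyond the scatter) from compound 3 to compound 4, 31 percentage points apart, beyond the scatter of two such steps. The size of this step therefore depends on the core, at least across these two pairs. The pairs do not show which difference between the cores matters, and they offer no rule for any further core.

Going by these compounds, it remains open how smaller or differently built amines at this place, such as piperidine, morpholine or dimethylamino, would behave on each core. Whether the gap between the cores would also appear with those groups is equally unsettled.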